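A few compounds are considered here, and "the series" means these few. Any claim that something is new, unique, unknown or untested is made for them only; others in the source may bear on it.

Compound 1 `COC(=O)[C@@H]1C[C@@]2(CC=C(C)C)c3ccccc3N3C(=N)[C@H](Cc4ccccc4)N1[C@H]32` gives 24100 nM in a functional assay on HT-29 cells (Homo sapiens) for cytotoxicity, read by sulforhodamine B assay, with a stated time of 48 h; a lower number here means that less compound is tolerated, a higher number that more compound is tolerated. Compound 2 `COC(=O)[C@@H]1C[C@@]2(CC=C(C)C)c3ccccc3N3C(=N)[C@H](c4ccccc4)N1[C@H]32` reaches only a limit of the assay, giving > 100000 nM in this assay. The step of an at least 4.1-fold higher number from compound 1 to compound 2 (0.61 log units; beyond the scatter) is thus known only as a bound (the limit of > 100000 nM in this assay, at which 1 of the 2 values shown sits). Compound 3 `COC(=O)[C@@H]1C[C@@]2(CC=C(C)C)c3ccccc3N3C(=N)[C@H](C(C)(C)C)N1[C@H]32` differs from compound 2 by tert-butyl in place of phenyl on a saturated ring carbon. Within the data shown here, no measured step replaces phenyl with tert-butyl; the step of an at least 4.1-fold higher number from compound 1 to compound 2 (0.61 log units; beyond the scatter) is the only one at this position, and it gives a floor rather than a size. Compound 3 is therefore expected to show a step of a number no higher from compound 2 to compound 3 (the limit leaves the size open) in this assay of no clear direction. The estimate for compound 3 is 100000 nM, within 30000 nM to 300000 nM.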

Compound 3, concentration lethal to 50% of the cells: > 100000 nM
Compound 3: a limit, no number (the forecaster's own chance of this, stated with the estimate: 65%); the middle value lies on the limit itself.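

In this assay, among these compounds, compound 3 also stands at a limit, so a tert-butyl group without a ring joins phenyl there, and benzyl remains the only group at this position with a number. Against compound 1, the change gives an at least 4.1-fold higher number from compound 1 to compound 3 (0.61 log units; beyond the scatter), again a floor rather than a size. The step between compound 2 and compound 3 cannot be read: the limit of > 100000 nM in this assay, at which 2 of the 3 values shown sit. Still open, as far as these compounds go, is whether a methyl group, an amine or a carboxylic acid on this carbon would give a number inside the assay's range. A longer chain ending in phenyl is equally unresolved.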